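The source may hold more compounds than are shown below. What is called first, only, known or untested is meant among the compounds shown, and "the series" means these compounds.

Measured compounds:
compound 1 `CC(C)(C)c1ccc(/C=C/C(=O)c2ccc(OCC(=O)N[C@H]3CCOC3=O)cc2)cc1` — 10600 nM
compound 2 `O=C(CNc1ccccc1)N[C@H]1CCOC1=O` — > 64000 nM
compound 3 `O=C1OCC[C@@H]1NC(=S)SCCOc1cccc2ccccc12` — > 64000 nM

Within the data shown here, in a functional assay on PC-3 cells (Homo sapiens) for antiproliferative activity, read by MTT assay, with a stated time of 72 h (on this read-out lower numbers stand for stronger inhibition and higher numbers for weaker inhibition), compound 1 gives 10600 nM, the only number among the three compounds measured. For compound 2 this assay reports only a limit, > 64000 nM. For compound 3 this assay likewise reports only a limit, > 64000 nM. Among the measured compounds shown here, compound 1 therefore stands as the single measured number here, set against (the limit of > 64000 nM in this assay, at which 2 of the 3 values shown sit).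

Compound 4 `O=C(COc1ccc(C(=O)/C=C/c2cccc(Cl)c2)cc1)N[C@H]1CCOC1=O` has not yet been measured in this assay. It shares its core with compound 1 and differs from it in one place: 3-chlorophenyl in place of 4-(tert-butyl)phenyl on a double-bonded chain carbon bound to a double-bonded chain carbon. For the measured compounds named here, no pair of measured compounds differing in a single place is available, so there is no measured step to judge the size of this change by. The two aromatic groups exchanged are of a similar kind, both six-membered rings of carbon only, with no donors or acceptors entering or leaving, so the expectation is a step that stays within the usual scatter, in no particular direction.

Compound 4 is expected to give about 12000 nM in this assay, within a range from 4000 nM to 40000 nM. That estimate means a 1.1-fold higher number from compound 1 to compound 4 (0.05 log units; within the scatter), a step expected to lie within the scatter of repeated measurements.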

Compound 4, half-maximal inhibitory concentration: 4990 nM
For compound 4 the middle estimate is 2.4-fold (0.38 log units) above the measured one; the range from low to high includes it.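

In this assay, exchanging 4-(tert-butyl)phenyl for 3-chlorophenyl gives a 2.1-fold lower number from compound 1 to compound 4 (0.33 log units; beyond the scatter), the first measured step available in this set. The step is modest but beyond the scatter, so the group at this place has a measurable bearing on the read-out, and the tert-butyl group is not required for a measurable number, as compound 4 gives 4990 nM without it. Nothing shown explains the step, and no measurement separates the possible contributions of the departing tert-butyl group, the entering chlorine or the place of that chlorine on the ring.

On these data alone, those contributions remain tied together in one exchange, so it stays open what an unsubstituted phenyl, a methoxy group or an amine on this ring would give. Among these compounds, the rest of the shared core has no one-place step of its own, which leaves the effect of a longer chain on the amide side open as well.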